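Piperazine thiocarbamate benzamide series: aryl variation on piperazine

This account rests on a few compounds, and the source may have more. Where it says the series, first, only, none or still open, it means among the compounds named here.

Measured so far in a functional assay on HeLa cells (Homo sapiens) for antiproliferative activity, read by CCK-8 assay, with a stated time of 72 h, tested at 2 uM; a lower number here means a weaker effect, a higher number a stronger effect of the compound at the concentration tested:
compound 1 `Nc1ccccc1NC(=O)c1ccc(CSC(=S)N2CCN(c3ccc(F)cc3)CC2)cc1`: 60.8%
compound 2 `Nc1ccccc1NC(=O)c1ccc(CSC(=S)N2CCN(c3ccccc3F)CC2)cc1`: 17.5%

Compound 2 stands lowest of the two numbers in this assay; its nearest neighbour is compound 1, whose value lies higher by the step of a number 43.3 percentage points lower from compound 1 to compound 2 (beyond the scatter), which is beyond the scatter and large. Going by the values given here, that single step, 2-fluorophenyl in place of 4-fluorophenyl on an amine nitrogen in a ring, is the only structural comparison available so far.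

Compound 3 `Nc1ccccc1NC(=O)c1ccc(CSC(=S)N2CCN(c3cnccn3)CC2)cc1` has not yet been measured. It differs from compound 2 by pyrazin-2-yl in place of 2-fluorophenyl on an amine nitrogen in a ring. Among the compounds with values here, no measured step bears on an exchange of this kind: the step from compound 1 to compound 2 concerns only where the fluorine sits on the phenyl, not a change of the ring itself. It shows that this position of the shared core is sensitive, so a step of appreciable size in either direction is possible. The expectation for compound 3 in this assay is therefore loose, with a middle estimate of 35% and a range from 10% to 65%, a step of a number 17.5 percentage points higher from compound 2 to compound 3 (beyond the scatter) from compound 2, which is expected rather than known.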

Compound 3, a percentage reported as inhibition, at one concentration (the size of the read-out at that concentration, not a potency): 70.4%
For compound 3 the middle estimate is 35.4 percentage points below the measured one; the whole stated range lies below it.
By their numbers in this assay, from the lowest: compound 2; then compounds 1 and 3 (each within the scatter of the next).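

In this assay this position accepts an exchange of the ring itself, not only a move of the fluorine: pyrazin-2-yl in place of 2-fluorophenyl gives a number 52.9 percentage points higher from compound 2 to compound 3 (beyond the scatter) and so restores a large read-out in a compound with no fluorine at all. Pyrazin-2-yl in place of 4-fluorophenyl gives a number 9.6 percentage points higher from compound 1 to compound 3 (within the scatter), so these two groups are not told apart in this assay at the tested concentration, and a fluorine-bearing phenyl is not required for a read-out of this size on the shared core. Of the three groups shown, only 2-fluorophenyl goes with a low number, and no measurement at hand gives a reason for either step.

The compounds shown leave open whether the read-out of compound 3 is particular to pyrazin-2-yl or would be shared by other groups on this amine nitrogen, such as an unsubstituted phenyl or an alkyl chain. With one tested concentration, the read-out also gives no potency, so any difference in potency between compound 1 and compound 3 remains unresolved.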